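The source may report more compounds than this note shows. Statements on the series, on what has been measured and on what is new or still open speak of the compounds shown alone.

Measured compounds:
Compound 1, `Cc1ccc(C2C(C#N)=C(N)N(c3ccc(S(N)(=O)=O)cc3)C3=C2CCCC3)cc1`, gives 80%
Compound 2, `N#CC1=C(N)N(c2ccc(S(N)(=O)=O)cc2)C2=C(CCCC2)C1c1ccccc1O`, gives 50%
Compound 3, `N#CC1=C(N)N(c2ccc(S(N)(=O)=O)cc2)C2=C(CCCC2)C1c1ccc(Cl)cc1Cl`, gives 50%

The three compounds share one core and differ only in the group on a saturated ring carbon. They were tested in a functional assay on Ehrlich cells (Mus musculus) for cytotoxicity, read by trypan blue exclusion, with a stated time of 2 h, tested at 50 ug/mL; on this read-out higher numbers stand for a stronger effect at the one concentration tested and lower numbers for a weaker effect. On these numbers compound 3 stands level with compound 2 at the digits printed, and together they are the lowest of the three; the step of no change at the digits printed from compound 2 to compound 3 (within the scatter) lies within the scatter, while the step of a number 30 percentage points lower from compound 1 to compound 3 (beyond the scatter) lies beyond it.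

The next compound, compound 4, `Cc1ccc(C2C(C#N)=C(N)N(c3ccc(S(N)(=O)=O)cc3)C3=C2CCCC3)o1`, differs from compound 3 in one place: 5-methylfuran-2-yl in place of 2,4-dichlorophenyl on a saturated ring carbon.

Among the compounds with values here, three measured steps bear on this change, since each also swaps the group on that saturated ring carbon. The steps of a number 30 percentage points lower from compound 1 to compound 2 (beyond the scatter) and a number 30 percentage points lower from compound 1 to compound 3 (beyond the scatter) show that such a swap can move the number modestly, whereas the step of no change at the digits printed from compound 2 to compound 3 (within the scatter) shows that it can also leave the number where it was. Within the data shown here, no compound measured here carries the 5-methylfuran-2-yl group, so the direction of its step cannot be read from the data. The most defensible expectation is a step that stays near zero or moves only modestly, so compound 4 is expected to show a number 5 percentage points higher from compound 3 to compound 4 (within the scatter). Compound 4 is therefore estimated at 55%, with a range from 35% to 80%.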

Compound 4, a percentage reported as activity, at one concentration (the size of the read-out at that concentration, not a potency): 10%
The estimate for compound 4 lay 45 percentage points above the measured number, outside the stated range (below it).
By their numbers in this assay, from the lowest: compound 4; then compounds 2 and 3 (each within the scatter of the next); then compound 1.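

Until now, swaps on this saturated ring carbon had moved the number modestly or not at all, but in this assay the 5-methylfuran-2-yl group gives a number 40 percentage points lower from compound 3 to compound 4 (beyond the scatter) and a number 40 percentage points lower from compound 2 to compound 4 (beyond the scatter), both large steps. Set against the 4-methylphenyl group, the same change gives a number 70 percentage points lower from compound 1 to compound 4 (beyond the scatter), the largest step in this small set, so the choice of group at this one position can take the number from the top of the series to the bottom. Within the data shown here, compound 4 is also the only compound here with a five-membered aromatic ring, and the three compounds with a six-membered aromatic ring of carbon only all stand above it, whether that ring carries methyl, hydroxy or chlorine.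

From the compounds shown here alone, it remains open whether the drop goes with the furan ring itself or with its methyl group, a question that an unsubstituted furan-2-yl, a thiophen-2-yl or a cyclohexyl group on this carbon would help to separate. Nothing available here explains why this group gives so much lower a number.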